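Naphthyl swap on the fluorobenzamide guanidine series

The source may report more compounds than this note shows. Statements on the series, on what has been measured and on what is new or still open speak of the compounds shown alone.

Measured so far:
compound 1, `CCN(CC)CCCC(C)/N=C(/N)NC(=O)c1cccc(F)c1CCc1ccc2ccccc2c1`, 1800 nM
compound 2, `CCN(CC)CCCC(C)/N=C(/N)NC(=O)c1cccc(F)c1CCc1cc(Br)ccc1OC`, 130 nM

In a functional assay for antagonist activity at Melanocortin receptor 4 (Homo sapiens), read by cAMP accumulation (a lower number here means a stronger inhibitor, a higher number a weaker inhibitor), compound 2 stands lowest of the two measured numbers; the nearest is compound 1, and a 14-fold lower number from compound 1 to compound 2 (1.14 log units; beyond the scatter). Compound 3, `CCN(CC)CCCC(C)/N=C(/N)NC(=O)c1cccc(F)c1CCc1cccc2ccccc12`, differs from compound 2 by naphthalen-1-yl in place of 5-bromo-2-methoxyphenyl on a saturated chain carbon, two bonds along the chain from an aromatic carbon. Among the compounds with values here, the only measured step that bears on this is a 14-fold lower number from compound 1 to compound 2 (1.14 log units; beyond the scatter), which moved a naphthyl group out and the bromo-methoxyphenyl in with a large drop. Reversing to a naphthyl, now the 1-isomer, is therefore expected to raise the number again, though the isomer change leaves room for a smaller shift. Compound 3 is estimated at 1000 nM, ranging from 300 nM to 4000 nM, a step of a 7.7-fold higher number from compound 2 to compound 3 (0.89 log units; beyond the scatter).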

Compound 3, half-maximal inhibitory concentration: 1500 nM
Compound 3: middle estimate off by 1.5-fold (0.18 log units), on the low side; low and high end bracket the measured number.
By their numbers in this assay, from the lowest: compound 2; then compounds 3 and 1 (each within the scatter of the next).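

In this assay, naphthalen-1-yl in place of 5-bromo-2-methoxyphenyl gives a 12-fold higher number from compound 2 to compound 3 (1.06 log units; beyond the scatter), so at this position the second naphthyl isomer also lacks the low number seen with 5-bromo-2-methoxyphenyl. The two isomers cannot be told apart here, with a 1.2-fold lower number from compound 1 to compound 3 (0.08 log units; within the scatter). Nothing available explains these results. Still open, as far as these compounds go, is whether the 5-bromo or the 2-methoxy group, or the pair, goes with the low number of compound 2. A phenyl carrying only one of them, or chlorine in place of the bromine, would address this.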